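Swapping the Ring on the Sulfonamide Nitrogen

The source may report more compounds than this note shows. Statements on the series, on what has been measured and on what is new or still open speak of the compounds shown alone.

Measured compounds:
Compound 1 `NS(=O)(=O)c1ccc(N/C(S)=N\c2ccnc3cc(C(F)(F)F)ccc23)cc1` gives 52900 nM
Compound 2 `N=C(N)NS(=O)(=O)c1ccc(N/C(S)=N\c2ccnc3cc(C(F)(F)F)ccc23)cc1` gives "not active" (no number reported)
Compound 3 `Cc1noc(NS(=O)(=O)c2ccc(N/C(S)=N\c3ccnc4cc(C(F)(F)F)ccc34)cc2)c1C` gives 27900 nM

All three share a core and differ only at the sulfonamide nitrogen. In a functional assay on MDA-MB-231 cells (Homo sapiens) for antiproliferative activity, read by sulforhodamine B assay, with a stated time of 48 h (on this read-out lower numbers stand for stronger inhibition and higher numbers for weaker inhibition), compound 3 holds the lowest of the two reported numbers, but the step of a 1.9-fold lower number from compound 1 to compound 3 (0.28 log units; within the scatter) lies within the scatter, so compound 1 and compound 3 cannot be told apart on these data. Compound 2 carries no number at all.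

Compound 4 `O=S(=O)(Nc1nccs1)c1ccc(N/C(S)=N\c2ccnc3cc(C(F)(F)F)ccc23)cc1` is the next step: 1,3-thiazol-2-yl in place of 3,4-dimethyl-1,2-oxazol-5-yl on a sulfonamide nitrogen. Among the measured compounds shown here, no measured pair shows this exact exchange of one five-membered heteroaromatic ring for another. For the measured compounds named here, the only related step, from hydrogen to the dimethyl-oxazolyl ring in a 1.9-fold lower number from compound 1 to compound 3 (0.28 log units; within the scatter), stayed within the scatter, so there is no sign that groups at this position move the number much. Compound 4 is therefore expected to stay close to compound 3, with a 1.1-fold higher number from compound 3 to compound 4 (0.03 log units; within the scatter) as the estimated step, which is no change beyond the scatter. The estimate for compound 4 in this assay is 30000 nM, within a range from 12000 nM to 80000 nM.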

Compound 4, half-maximal inhibitory concentration: 24400 nM
Compound 4: middle estimate off by 1.2-fold (0.09 log units), on the high side; the range from low to high includes it.
By their numbers in this assay, from the lowest: compounds 4, 3 and 1 (each within the scatter of the next, the first and the last beyond it).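

Exchanging one five-membered aromatic ring for another on the sulfonamide nitrogen gives a 1.1-fold lower number from compound 3 to compound 4 (0.06 log units; within the scatter) in this assay, so the 3,4-dimethyl-1,2-oxazol-5-yl and 1,3-thiazol-2-yl rings cannot be told apart here, despite their different heavy-atom counts. Against plain hydrogen, the thiazolyl ring gives a 2.2-fold lower number from compound 1 to compound 4 (0.34 log units; beyond the scatter), the first step at this position to pass the scatter, although it is modest and the oxazolyl ring in compound 3 does not clear the scatter against compound 1. Nothing available explains this small difference between the two rings in their steps from hydrogen.

On these data alone, whether a group without a ring on this nitrogen, such as an acetyl group or an ethyl chain, would behave like hydrogen or like these rings stays open. So does the outcome with a six-membered ring such as pyridine.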